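The source may report more compounds than this note shows. Statements on the series, on what has been measured and on what is new or still open speak of the compounds shown alone.

In a functional assay on B16 cells (Mus musculus) for antiproliferative activity, read by MTT assay, with a stated time of 24 h (a lower number here means a stronger inhibitor, a higher number a weaker inhibitor), compound 1 `C#CCOc1ccc2c(=O)c(-c3cc(OC)c(OC)cc3OC)coc2c1` gives 4500 nM. Compound 2 `COc1cc(OC)c(-c2coc3cc(OCc4ccc([N+](=O)[O-])cc4)ccc3c2=O)cc1OC` returns no number, only a limit of the assay, > 10000 nM. It therefore stands at the limit of > 10000 nM in this assay, at which 1 of the 2 values shown sits. Among the measured compounds shown here, the one measured step is an at least 2.2-fold higher number from compound 1 to compound 2 (0.34 log units; beyond the scatter), with 4-nitrophenyl in place of ethynyl on a saturated chain carbon bound to an oxygen on an aromatic ring. Compound 3 `COc1cc(OC)c(-c2coc3cc(OCc4cccc(Cl)c4)ccc3c2=O)cc1OC` changes that same group, and its difference is 3-chlorophenyl in place of 4-nitrophenyl on a saturated chain carbon bound to an oxygen on an aromatic ring. For the measured compounds named here, no measured step exchanges one substituted phenyl for another, so the step to compound 2 is the only guide, and its size is known only as a limit. In this assay, a modest move toward a lower number is therefore expected, and compound 3 may also stay at the limit. The expected step is an at least 1.2-fold lower number from compound 2 to compound 3 (0.09 log units; that floor lies within the scatter). For compound 3 the estimated value is 8000 nM, with an expected range of 3000 nM to 20000 nM.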

Compound 3, half-maximal inhibitory concentration: 2280 nM
Compound 3: middle estimate off by 3.5-fold (0.55 log units), on the high side, and the stated range ends above it.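

In this assay, a substituted phenyl at this place, on a saturated chain carbon bound to an oxygen on an aromatic ring, does not always leave the compound at the limit: the change to 3-chlorophenyl gives an at least 4.3-fold lower number from compound 2 to compound 3 (0.64 log units; beyond the scatter). The weak result therefore belongs to 4-nitrophenyl, not to every phenyl group here, and the other new step, a 2.0-fold lower number from compound 1 to compound 3 (0.30 log units; within the scatter), does not separate 3-chlorophenyl from ethynyl. The true size of the first step stays unknown, and it can be read only as a floor: the limit of > 10000 nM in this assay, at which 1 of the 3 values shown sits.

The compounds shown do not tell whether the chlorine or its place on the phenyl ring matters, for no phenyl carries the same group at both places. On these data alone, how an unsubstituted benzyl, or an amine or carboxylic acid on this chain, would read also remains open.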